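Swapping the aryl for a methoxyphenyl amide group

The compounds below may be only part of what the source reports. "The series", "measured", "known", "first", "only" and "open" are said of these compounds alone.

Compound 3 `CCOC(=O)C1=Cc2ccccc2OC1(OCc1cn(-c2ccc(F)c(Cl)c2)nn1)C(F)(F)F` carries the shared core with a 3-chloro-4-fluorophenyl on an aromatic nitrogen. In a functional assay on HeLa cells (Homo sapiens) for inhibition, read by MTT assay, with a stated time of 24 h (on this read-out higher numbers stand for weaker inhibition and lower numbers for stronger inhibition), compound 3 gives 22700 nM, the lowest of the two numbers shown. Compound 2 `CCOC(=O)C1=Cc2ccccc2OC1(OCc1cn(CC(=O)Nc2ccc(C)cc2)nn1)C(F)(F)F` gives 67400 nM in this assay. Compound 1 `CCOC(=O)C1=Cc2ccccc2OC1(OCc1cn(CC(=O)Nc2cccc(F)c2)nn1)C(F)(F)F` reaches only > 150000 nM in this assay, which is a limit rather than a number. Compound 4 `CCOC(=O)C1=Cc2ccccc2OC1(OCc1cn(CC(=O)Nc2ccc(OC)cc2)nn1)C(F)(F)F` has not yet been measured; it differs from compound 3 by ((4-methoxyphenyl)carbamoyl)methyl in place of 3-chloro-4-fluorophenyl on an aromatic nitrogen.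

Among the measured compounds shown here, two measured steps bear on this change, both running the opposite way: a 3.0-fold lower number from compound 2 to compound 3 (0.47 log units; beyond the scatter) and an at least 6.6-fold lower number from compound 1 to compound 3 (0.82 log units; beyond the scatter). Each time a carbamoylmethyl group gave way to 3-chloro-4-fluorophenyl, the number fell. Going back from 3-chloro-4-fluorophenyl to ((4-methoxyphenyl)carbamoyl)methyl is therefore expected to raise the number, landing near where compound 2 sits. Compound 4 is estimated at 70000 nM, with a range from 25000 nM to 200000 nM. That estimate means an expected step of a 3.1-fold higher number from compound 3 to compound 4 (0.49 log units; beyond the scatter).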

Compound 4, half-maximal inhibitory concentration: 31900 nM
Compound 4: middle estimate off by 2.2-fold (0.34 log units), on the high side; low and high end bracket the measured number.
By their numbers in this assay, from the lowest: compounds 3 and 4 (each within the scatter of the next); then compound 2. At a limit, above all of these: compound 1.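

In this assay, a carbamoylmethyl group on this aromatic nitrogen no longer reads as clearly different from 3-chloro-4-fluorophenyl, which the earlier amides did not show: a 1.4-fold higher number from compound 3 to compound 4 (0.15 log units; within the scatter). The outcome therefore depends on the aryl group at the far end of the amide, not just on the presence of the amide chain: methoxy in place of methyl gives a 2.1-fold lower number from compound 2 to compound 4 (0.32 log units; beyond the scatter), and 4-methoxyphenyl in place of 3-fluorophenyl gives an at least 4.7-fold lower number from compound 1 to compound 4 (0.67 log units; beyond the scatter). The second of these steps has only a lower bound, as compound 1 is held at a limit and not a number: the limit of > 150000 nM in this assay, at which 1 of the 4 values shown sits.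

The compounds shown leave open how a hydroxy or a dimethylamino group in place of the methoxy would read. They also leave open whether a longer chain between the aromatic nitrogen and the amide would shift the number.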